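The compounds below may be only part of what the source reports. "The series", "measured", "known", "first", "only" and "open" are said of these compounds alone.

Measured so far:
- compound 1, `COc1cc(OC)c(OC)cc1/C=C/COC(=O)/C=C/c1ccc(OC)c(OC)c1`: 100%
- compound 2, `COc1cccc(/C=C/C(=O)OC/C=C/c2cc(OC)c(OC)cc2OC)c1`: 100%

In a functional assay on the whole organism (strain Kunming) with Mus musculus as the target, with a stated time of 0.5 h, at a dose of 300 mg/kg by the intraperitoneal route (a higher number here means a weaker effect of the compound at the dose given, a lower number a stronger effect), compound 2 stands level with compound 1; the step of no change at the digits printed from compound 1 to compound 2 (within the scatter) shows that removing one methoxy group from an aromatic ring left the read-out unchanged. Compound 3, `COc1cc(OC)c(OC)cc1/C=C/COC(=O)/C=C/c1ccc(Cl)cc1`, differs from compound 2 by 4-chlorophenyl in place of 3-methoxyphenyl on a double-bonded chain carbon bound to a double-bonded chain carbon. Going by the values given here, the only step available on this series, from compound 1 to compound 2, also alters the substitution of that same aromatic ring and brought no change beyond the scatter, so a step of about a number 3 percentage points lower from compound 2 to compound 3 (within the scatter) is expected, which is no change beyond the scatter. The value of compound 3 in this assay is therefore estimated at 97%, within 82% to 100%.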

Compound 3, a percentage reported as activity, at one dose (the size of the read-out at that dose, not a potency): 100%
For compound 3 the middle estimate is 3 percentage points below the measured one; the measured number falls inside the stated range.
By their numbers in this assay, from the lowest: compounds 1, 2 and 3 (each within the scatter of the next).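

At this position, on a double-bonded chain carbon bound to a double-bonded chain carbon, 4-chlorophenyl in place of 3-methoxyphenyl gives no change at the digits printed from compound 2 to compound 3 (within the scatter) in this assay, and 4-chlorophenyl in place of 3,4-dimethoxyphenyl gives no change at the digits printed from compound 1 to compound 3 (within the scatter). Going by these compounds alone, the earlier compounds carried only methoxy groups on this ring, so this is the first sign that a ring with chlorine instead reads the same. No evidence is available to explain this result. Still open, going by these compounds, is whether a ring bearing an amine or a carboxylic acid would shift the read-out at this position.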